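Swapping an acetylphenyl for an indole in desaturase inhibitors

This account rests on a few compounds, and the source may have more. Where it says the series, first, only, none or still open, it means among the compounds named here.

Compound 1, `Cc1ccccc1OC1CCN(c2ccc(-n3ccnc3)nn2)CC1`: 39 nM
Compound 2, `Cc1cccc(OC2CCN(c3ccc(-n4ccnc4)nn3)CC2)c1`: 251 nM
Compound 3, `CC(=O)c1ccccc1OC1CCN(c2ccc(-n3ccnc3)nn2)CC1`: 34 nM

Three compounds share one core and differ only in the aromatic group attached through an oxygen on a saturated carbon. In an assay on microsomes from liver for inhibition of acyl-CoA desaturase 1 (Rattus norvegicus) (a higher number here means a weaker inhibitor, a lower number a stronger inhibitor), compound 3 gives the lowest number of the three, with compound 1 close by and compound 2 far off. The steps behind this are a 1.1-fold lower number from compound 1 to compound 3 (0.06 log units; within the scatter) and a 7.4-fold lower number from compound 2 to compound 3 (0.87 log units; beyond the scatter); the move of a methyl to a different ring position gave a 6.4-fold higher number from compound 1 to compound 2 (0.81 log units; beyond the scatter).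

Compound 4, `c1cc(OC2CCN(c3ccc(-n4ccnc4)nn3)CC2)c2cc[nH]c2c1`, is not yet measured. Its change from compound 3 is 1H-indol-4-yl in place of 2-acetylphenyl on an oxygen on a saturated carbon. For the measured compounds named here, no measured step covers a fused ring or a hydrogen-bond donor, so the closest guide is that a change of the attached group left the number within the scatter in a 1.1-fold lower number from compound 1 to compound 3 (0.06 log units; within the scatter), while a shift of the substituent's position cost a 6.4-fold higher number from compound 1 to compound 2 (0.81 log units; beyond the scatter). A modest step, more likely toward a higher number, is therefore expected. For compound 4 in this assay the estimate is 80 nM, ranging from 25 nM to 260 nM, which means an expected step of a 2.4-fold higher number from compound 3 to compound 4 (0.37 log units; beyond the scatter).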

Compound 4, half-maximal inhibitory concentration: 162 nM
Estimate against measurement, compound 4: 2.0-fold (0.31 log units) below; measured number inside the range.
By their numbers in this assay, from the lowest: compounds 3 and 1 (each within the scatter of the next); then compounds 4 and 2 (each within the scatter of the next).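

In this assay, the 1H-indol-4-yl group, which brings a hydrogen-bond donor and a five-membered aromatic ring, does not match the 2-acetylphenyl it replaces (a 4.8-fold higher number from compound 3 to compound 4 (0.68 log units; beyond the scatter)) or the 2-methylphenyl of compound 1 (a 4.2-fold higher number from compound 1 to compound 4 (0.62 log units; beyond the scatter)), so this position on the oxygen does not accept every aromatic group equally. Set against the 3-methylphenyl group, the change gives a 1.5-fold lower number from compound 2 to compound 4 (0.19 log units; within the scatter), so a fused ring carrying a hydrogen-bond donor and a simple methyl-bearing phenyl give numbers that cannot be told apart here. Nothing shown explains why the 1H-indol-4-yl group reads as it does.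

The compounds shown leave open whether the fused ring or the indole's nitrogen hydrogen accounts for the step, a question that a methyl group on that nitrogen or a benzofuran, with oxygen in the nitrogen's place, could help to separate. Also open, on these data alone, is how a phenyl bearing an amine or a carboxylic acid in place of the acetyl would read in this assay at this position.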